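Ethoxy to methoxy on a bromo compound

The source may hold more compounds than are shown below. What is called first, only, known or untested is meant among the compounds shown, and "the series" means these compounds.

Compound 1 `CCOCCOC(=O)C(=O)Nc1nc(-c2cc(Cl)no2)cs1`: > 30 mg/kg
Compound 2 `CCOCCOC(=O)C(=O)Nc1nc(-c2cc(Br)no2)cs1`: > 30 mg/kg

In a functional assay on the whole organism with Rattus norvegicus as the target (on this read-out lower numbers stand for an effect already at smaller amounts and higher numbers for an effect only at larger amounts of compound), compound 2 gives > 30 mg/kg, a limit and not a number. Compound 1 gives > 30 mg/kg, also a limit. Compound 3 `COCCOC(=O)C(=O)Nc1nc(-c2cc(Br)no2)cs1` differs from compound 2 by hydrogen in place of methyl on a saturated chain carbon bound to an oxygen on a saturated carbon, turning ethoxy into methoxy. For the measured compounds named here, the only measured step, a step that the two limits leave unreadable from compound 1 to compound 2, is a different change, bromo in place of chloro on an aromatic carbon, and offers no size to carry over. No step beyond the scatter is therefore expected in this assay, in either direction. For compound 3 the expected value is 35 mg/kg, with an estimated range of 15 mg/kg to 80 mg/kg. This estimate means an expected step that the limit leaves unreadable from compound 2 to compound 3.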

Compound 3, dose for half-maximal effect: > 100 mg/kg
Compound 3 gave a limit, no number; the forecaster's own chance of this, stated with the estimate: 65%; middle value at least 2.8-fold (0.45 log units) from the limit.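

For the compounds shown here, compound 2 and compound 3 each give only a limit in this assay, so no step between them can be read. From the compounds shown here alone, whether ethoxy and methoxy truly differ here, and at what dose either compound acts, stays open.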